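The compounds below may be only part of what the source reports. "The series", "measured", "known", "first", "only" and "open" are said of these compounds alone.

Compound 1 `CCc1nn(CCCN2CCN(c3ccc(C)cc3)CC2)c(=O)c(N)c1C(C)=O` carries an acetyl group on its core. Among the compounds with values here, in a functional assay on the whole organism (Abdomen, strain Swiss) for inhibition, with Mus musculus as the target, with stated times of 30 min, 10 min and 5 min, at a dose of 40 mg/kg by the oral route (a lower number here means a weaker effect, a higher number a stronger effect of the compound at the dose given), compound 1 gives 41%, the higher of the two numbers known so far; compound 2 `CCCC(=O)c1c(C)nn(CCCN2CCN(c3ccc(C)cc3)CC2)c(=O)c1N` gives 32% in this assay, a gap that lies within the usual scatter, so no order between the two is claimed. Compound 3 `C=Cc1c(CC)nn(CCCN2CCN(c3ccc(C)cc3)CC2)c(=O)c1N` differs from compound 1 in one place: vinyl in place of acetyl on an aromatic carbon. Within the data shown here, no measured pair shows the effect of such a change, so the step is expected to be small, a number 6 percentage points lower from compound 1 to compound 3 (within the scatter), most likely not beyond the scatter. Compound 3 is accordingly estimated at 35% in this assay, with a range from 15% to 55%.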

Compound 3, a percentage reported as inhibition, in the whole organism at one dose (the size of the read-out at that dose, not a potency): 28%
Compound 3: the middle estimate sits 7 percentage points above what was measured; measured number inside the range.
By their numbers in this assay, from the lowest: compounds 3, 2 and 1 (each within the scatter of the next, the first and the last beyond it).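

Within the data shown here, exchanging acetyl for vinyl on this aromatic carbon, opposite the ring nitrogen, gives in this assay a number 13 percentage points lower from compound 1 to compound 3 (beyond the scatter), a modest step, but the first single-place change that can be read. The value at this dose therefore depends on the group at this position, with the amino and ethyl groups held constant. Nothing available accounts for the step.

Only these two groups have been compared at this carbon. Going by these compounds, how a carboxylic acid, an aminomethyl group or a longer ketone chain would read here remains open.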